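Piperazine for Piperidine: What Compound 4 Should Deliver

A few compounds are considered here, and "the series" means these few. Any claim that something is new, unique, unknown or untested is made for them only; others in the source may bear on it.

Compound 1 `COc1cc(OC)c(Cl)c(-c2ccc3c(NC(=O)c4ccc(N5CCCCC5)cc4)n[nH]c3n2)c1Cl` carries a piperidin-1-yl group on an aromatic carbon of the shared core's pendant ring. In a functional assay on NCI-H1581 cells (Homo sapiens) for antiproliferative activity, read by CCK-8 assay, with a stated time of 72 h (on this read-out higher numbers stand for weaker inhibition and lower numbers for stronger inhibition), compound 1 gives 558 nM, the highest of the two proper numbers shown; the nearest is compound 2 `COc1cc(OC)c(Cl)c(-c2ccc3c(NC(=O)c4ccc(N5CCN(C(C)C)CC5)cc4)n[nH]c3n2)c1Cl`, which in this assay gives 1.4 nM, so that the step reads a 400-fold lower number from compound 1 to compound 2 (2.60 log units; beyond the scatter). A third value is only a limit (the limit of > 1000 nM in this assay, at which 1 of the 3 values shown sits). In this assay compound 3 `COc1cc(OC)c(Cl)c(-c2ccc3c(NC(=O)c4ccccc4)n[nH]c3n2)c1Cl` gives only that limit, > 1000 nM. The step of an at least 1.7-fold higher number from compound 1 to compound 3 (0.25 log units; that floor lies within the scatter), whereas an at least 710-fold higher number from compound 2 to compound 3 (2.85 log units; beyond the scatter).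

Compound 4 `COc1cc(OC)c(Cl)c(-c2ccc3c(NC(=O)c4ccc(N5CCNCC5)cc4)n[nH]c3n2)c1Cl` differs from compound 1 by piperazin-1-yl in place of piperidin-1-yl on an aromatic carbon. The step from compound 1 to compound 2 bears most directly on this change, since compound 2 also carries a piperazin-1-yl ring, there bearing an isopropyl group; that step was large and downward. The step from compound 1 to compound 3 shows that removing the ring entirely leaves the number at least as high. Compound 4 is therefore expected to move strongly toward compound 2, though it lacks the isopropyl group, so the estimate is set somewhat above compound 2. For compound 4 the expected value in this assay is 6 nM, with a range from 1.5 nM to 40 nM, meaning an estimated step of a 93-fold lower number from compound 1 to compound 4 (1.97 log units; beyond the scatter).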

Compound 4, half-maximal inhibitory concentration: 1.4 nM
For compound 4 the middle estimate is 4.3-fold (0.63 log units) above the measured one; measured number outside the range, below it.
By their numbers in this assay, from the lowest: compounds 2 and 4 (each within the scatter of the next); then compound 1. At a limit, above all of these: compound 3.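

In this assay, the exchange of piperidin-1-yl for piperazin-1-yl alone gives a 400-fold lower number from compound 1 to compound 4 (2.60 log units; beyond the scatter), so the large drop seen earlier with compound 2 does not depend on the isopropyl group: removing that group gives no change at the digits printed from compound 2 to compound 4 (within the scatter). Among these compounds, then, the amine nitrogen in the ring marks the difference from compound 1, whether it carries hydrogen or isopropyl. Against the unsubstituted compound 3, the piperazin-1-yl ring gives an at least 710-fold lower number from compound 3 to compound 4 (2.85 log units; beyond the scatter), and that figure is only a floor, since compound 3 gives a limit and not a number: the limit of > 1000 nM in this assay, at which 1 of the 4 values shown sits.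

The compounds shown leave open whether a morpholin-4-yl ring, with an oxygen in place of the amine nitrogen, would keep the number near that of compound 4 or return it toward that of compound 1. They also leave open whether an acetyl group or a longer chain such as 2-hydroxyethyl on the amine nitrogen would be accepted as hydrogen and isopropyl are.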